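A few compounds are considered here, and "the series" means these few. Any claim that something is new, unique, unknown or untested is made for them only; others in the source may bear on it.

Measured in a functional assay on DU-145 cells (Homo sapiens) for inhibition, read by trypan blue exclusion, with a stated time of 96 h; on this read-out lower numbers stand for stronger inhibition of growth and higher numbers for weaker inhibition of growth:

- compound 1 `O=C(/C(=C\c1ccc(O)c([N+](=O)[O-])c1)SCc1ccc(Br)cc1)c1c(F)c(F)c(F)c(F)c1F` gives 10000 nM
- compound 2 `O=C(O)c1ccc(C(=O)/C(=C\c2ccc(O)c([N+](=O)[O-])c2)SCc2ccc(Br)cc2)cc1` gives 50000 nM
- compound 3 `COc1ccc(C(=O)/C(=C\c2ccc(O)c([N+](=O)[O-])c2)SCc2ccc(Br)cc2)cc1` gives 10000 nM

Compound 1 stands level with compound 3, and the two share the lowest number of the three: no change at the digits printed from compound 1 to compound 3 (within the scatter). Among the compounds with values here, the only higher number belongs to compound 2: a 5.0-fold higher number from compound 1 to compound 2 (0.70 log units; beyond the scatter). The unmeasured compound 4 `O=C(/C(=C\c1ccc([N+](=O)[O-])c(O)c1)SCc1ccc(Br)cc1)c1c(F)c(F)c(F)c(F)c1F` keeps the rest of compound 1 and carries 3-hydroxy-4-nitrophenyl in place of 4-hydroxy-3-nitrophenyl on a double-bonded chain carbon bound to a double-bonded chain carbon.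

Within the data shown here, no measured step touches this group. All three change the group on the carbonyl carbon, and the third is a 5.0-fold lower number from compound 2 to compound 3 (0.70 log units; beyond the scatter). They therefore bear on compound 4 only indirectly, showing that this assay has moved modestly or not at all across this small set. The data give no direction for the new change, so no step beyond the scatter is expected, and the estimated step is no change at the digits printed from compound 1 to compound 4 (within the scatter). Among the measured compounds shown here, with no direct precedent, the range is kept wide. For compound 4 the estimate is 10000 nM, with an expected range of 3000 nM to 40000 nM.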

Compound 4, concentration for 50% growth inhibition: 10000 nM
Compound 4: the middle estimate sits on the measured number at the digits printed; low and high end bracket the measured number.
By their numbers in this assay, from the lowest: compounds 1, 3 and 4 (each within the scatter of the next); then compound 2.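

Within the data shown here, compound 4 gives the first reading at this place: in this assay, 3-hydroxy-4-nitrophenyl in place of 4-hydroxy-3-nitrophenyl on a double-bonded chain carbon bound to a double-bonded chain carbon gives no change at the digits printed from compound 1 to compound 4 (within the scatter). The earlier compounds shown here differed only in the group on the carbonyl carbon, so they said nothing about this place; with 2,3,4,5,6-pentafluorophenyl held constant, this read-out does not distinguish these two arrangements of the same hydroxy and nitro groups. No supporting measurement is available to explain this result.

The compounds shown leave open whether the same exchange would also stay within the scatter with 4-methoxyphenyl or 4-carboxyphenyl on the carbonyl carbon, since each of these has been read with only the 4-hydroxy-3-nitrophenyl group. They also leave open how growth inhibition would respond if an amine or a nitrile took the place of the nitro group, or a methoxy group took the place of the hydroxy group, on this ring.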